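This account rests on a few compounds, and the source may have more. Where it says the series, first, only, none or still open, it means among the compounds named here.

Measured so far:
compound 1, `CCN(CC)CCCn1c(=O)/c(=C/c2ccc(F)cc2F)s/c1=C1\C(=O)Nc2cc(F)ccc21`: 3690 nM
compound 2, `CCN(CC)CCCn1c(=O)/c(=C/c2cc(OC)c(OC)c(OC)c2)s/c1=C1\C(=O)Nc2ccc(Cl)cc21`: 820 nM
compound 3, `CN(C)CCn1c(=O)/c(=C/c2ccc(O)cc2)s/c1=C1/C(=O)Nc2ccc(F)cc21`: 1300 nM

All three numbers come from a functional assay on K562 cells (Homo sapiens) for cytotoxicity, read by sulforhodamine B assay, with a stated time of 48 h; on this read-out higher numbers stand for weaker inhibition and lower numbers for stronger inhibition. Compound 2 gives the lowest of the three; compound 3 lies within the scatter of it, while compound 1 sits beyond the scatter. Compound 4, `CCN(CC)CCCn1c(=O)/c(=C/c2cc(OC)c(OC)c(OC)c2)s/c1=C1/C(=O)Nc2ccc(Cl)cc21`, is the next to measure. Its relation to compound 2 is the two compounds have the same atoms and bonds and differ only in configuration as drawn: 1 of 2 stereo elements differ; a double bond is drawn Z in compound 2 and E in compound 4. Going by the values given here, no step between measured compounds isolates such a change. Since compound 2 gives 820 nM and the change touches no atom or bond, compound 4 is expected to land close to it, with a 1.2-fold higher number from compound 2 to compound 4 (0.09 log units; within the scatter), a step expected at most around the edge of the scatter and with no direction that can be fixed. The estimate for compound 4 is 1000 nM, in a range from 400 nM to 2800 nM.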

Compound 4, half-maximal inhibitory concentration: 820 nM
Compound 4: the middle estimate sits 1.2-fold (0.09 log units) above what was measured; measured number inside the range.
By their numbers in this assay, from the lowest: compounds 2, 4 and 3 (each within the scatter of the next); then compound 1.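

In this assay, going by these compounds alone, reversing the drawn geometry of one double bond gives no change at the digits printed from compound 2 to compound 4 (within the scatter), the first step that isolates a single change. At this double bond, with this substitution, the drawn configuration does not separate the two compounds on this read-out. The comparison rests on one point only: the fact that compounds 2 and 4 differ only in the configuration as drawn.

As far as these compounds go, whether the double-bond configuration is equally silent on other substitution patterns remains open. Also open, from the compounds shown here alone, is how a morpholine in place of the diethylamino group would read out in this assay on either geometry.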